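A few compounds are considered here, and "the series" means these few. Any claim that something is new, unique, unknown or untested is made for them only; others in the source may bear on it.

Measured compounds:
Compound 1, `CC(C)OCCCNC(=O)c1csc(Nc2ccc(Cl)c(Cl)c2)n1`: in an ADME assay on MDCK cells (Canis lupus familiaris) for cytotoxicity, with a stated time of 48 h (a higher number here means that more compound is tolerated, a lower number that less compound is tolerated), compound 1 gives 100000 nM.
Compound 2, `CCOCCCNC(=O)c1csc(Nc2ccc(Cl)c(Cl)c2)n1`: in this assay compound 2 reaches only a limit of the assay, > 100000 nM.
Compound 3, `CC(C)OCCCNC(=O)c1csc(Nc2ccc(Cl)c(F)c2)n1`: in this assay compound 3 also reaches only a limit of the assay, > 100000 nM.

The three measured compounds share one core and differ at two places. From compound 1 to compound 2 the change is hydrogen in place of methyl on a saturated chain carbon bound to an oxygen on a saturated carbon and a saturated chain carbon, and in this assay this gives a number no lower from compound 1 to compound 2 (the limit leaves the size open). The two cores of compound 1 and compound 3 differ by fluoro in place of chloro on an aromatic carbon, and in this assay that gives a number no lower from compound 1 to compound 3 (the limit leaves the size open). Neither step can be sized, because the limit of > 100000 nM in this assay, at which 2 of the 3 values shown sit, caps two of the three readings.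

Compound 4, `CCOCCCNC(=O)c1csc(Nc2ccc(Cl)c(F)c2)n1`, has not yet been measured. It stands to compound 3 as compound 2 stands to compound 1: the change is hydrogen in place of methyl on a saturated chain carbon bound to an oxygen on a saturated carbon and a saturated chain carbon, and its place reads word for word the same as in the measured pair, so it is the same change made on the other core.

Compound 4 is expected to sit at the same limit of this assay, a step of a number no higher from compound 3 to compound 4 (the limit leaves the size open), which rests on compound 3 having already reached that limit and on the measured pair showing no fall from compound 1 to compound 2. Compound 4 is thus estimated at 100000 nM, within 70000 nM to 200000 nM.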

Compound 4, half-maximal cytotoxic concentration: > 100000 nM
Compound 4 ended at the assay's limit; the forecaster's own chance of this, stated with the estimate: 80%; the middle value lies on the limit itself.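

In this assay compound 4 gives > 100000 nM as a limit of the assay. Its steps from compound 2 and from compound 3 cannot be read, because those compounds sit at the same limit: the limit of > 100000 nM in this assay, at which 3 of the 4 values shown sit.

The compounds shown leave open how much of compound 2, compound 3 or compound 4 is tolerated beyond this limit, and so whether either change alters the reading at all.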